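A few compounds are considered here, and "the series" means these few. Any claim that something is new, unique, unknown or untested is made for them only; others in the source may bear on it.

In a functional assay on HepG2 cells (Homo sapiens) for cytotoxicity, read by MTT assay, with a stated time of 48 h (on this read-out higher numbers stand for weaker inhibition and lower numbers for stronger inhibition), compound 1 `O=C1/C(=C\c2ccccc2)S/C(=N/c2ccccc2)N1Cc1ccncc1` gives 25200 nM. Among the measured compounds shown here, compound 2 `O=C1/C(=C\c2ccc(O)cc2)S/C(=N/c2ccccc2)N1Cc1ccncc1`, with hydroxy in place of hydrogen on an aromatic carbon, gives 11800 nM, the lower of the two numbers so far. Compound 3 `COc1ccc(/C=C2/S/C(=N/c3ccccc3)N(Cc3ccncc3)C2=O)cc1` turns that hydroxy into methoxy, placing methyl in place of hydrogen on an oxygen on an aromatic ring. For the measured compounds named here, only one measured step bears on this change: a 2.1-fold lower number from compound 1 to compound 2 (0.33 log units; beyond the scatter). That modest step adds the hydroxy and does not alter it, so the data offer no direct guide to capping its oxygen. A step no larger than that one is therefore expected, and its direction is uncertain. The expected result is a 1.3-fold higher number from compound 2 to compound 3 (0.10 log units; within the scatter), a shift not expected to exceed the scatter in this assay. Compound 3 is estimated at 15000 nM, with an expected range of 7000 nM to 32000 nM.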

Compound 3, half-maximal inhibitory concentration: 19100 nM
Compound 3: middle estimate off by 1.3-fold (0.10 log units), on the low side; the range from low to high includes it.
By their numbers in this assay, from the lowest: compounds 2, 3 and 1 (each within the scatter of the next, the first and the last beyond it).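

In this assay, putting methyl on the oxygen gives a 1.6-fold higher number from compound 2 to compound 3 (0.21 log units; within the scatter), while the methoxy group set against plain hydrogen gives a 1.3-fold lower number from compound 1 to compound 3 (0.12 log units; within the scatter). Compound 3 therefore cannot be told apart from either of the other two, even though compound 1 and compound 2 lie beyond the scatter of each other, so the hydrogen on the hydroxy oxygen is shown to be neither needed nor dispensable for the modest gain seen with the hydroxy group. Nothing measured here explains this result.

Going by these compounds, it remains open whether a longer chain on the same oxygen, such as ethoxy, would give a number beyond the scatter. The same question stands for an amine or a carboxylic acid in place of the hydroxy group.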